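A few compounds are considered here, and "the series" means these few. Any claim that something is new, unique, unknown or untested is made for them only; others in the source may bear on it.

Series notes. Compound 2 `COc1cc(-c2nn(-c3cccc(NC(=O)Nc4cccc(C(F)(F)F)c4)c3)cc2-c2ccncc2)ccc1Cl` carries a methyl in place of hydrogen on an oxygen on an aromatic ring relative to compound 1 `O=C(Nc1cccc(-n2cc(-c3ccncc3)c(-c3ccc(Cl)c(O)c3)n2)c1)Nc1cccc(C(F)(F)F)c1`. In a functional assay on SNB-19 cells (Homo sapiens) for inhibition, read by sulforhodamine B assay, with a stated time of 48 h (a higher number here means that more compound is tolerated, a lower number that less compound is tolerated), compound 1 gives only a limit, > 32500 nM. In this assay compound 2 likewise gives only a limit, > 50000 nM. The step that the two limits leave unreadable from compound 1 to compound 2 is thus not readable; the limit of > 32500 nM in this assay, at which 1 of the 2 values shown sits, and the limit of > 50000 nM in this assay, at which 1 of the 2 values shown sits, are all that the numbers show. Compound 2 therefore stands at the assay limit, with no number beneath it.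

Compound 3 `COc1cc(-c2nn(-c3cccc(NC(=O)c4ccccc4)c3)cc2-c2ccncc2)ccc1Cl` differs from compound 2 by phenyl in place of (3-(trifluoromethyl)phenyl)amino on a carbonyl carbon. Going by the values given here, no measured step touches this carbonyl carbon; the single step measured, between compound 1 and compound 2, sits elsewhere and is itself unreadable, so nothing measured bears on the present change. Any expected outcome in this assay rests on the two limits alone. Compound 3 is expected to give a limit again, estimated at 50000 nM, within 15000 nM to 150000 nM. The expected step of a number no higher from compound 2 to compound 3 (the limit leaves the size open) is none beyond the scatter.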

Compound 3, concentration lethal to 50% of the cells: > 100000 nM
Compound 3: no number, only a limit; the forecaster's own chance of this, stated with the estimate: 70%; middle value at least 2.0-fold (0.30 log units) away from the limit.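

Compound 2 and compound 3 both give only limits in this assay, so the step between them cannot be read. The compounds shown leave open where the actual values of compound 1, compound 2 and compound 3 lie, and whether phenyl in place of (3-(trifluoromethyl)phenyl)amino on a carbonyl carbon shifts the read-out at all.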